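The source may report more compounds than this note shows. Statements on the series, on what has been measured and on what is new or still open speak of the compounds shown alone.

Compound 1, with structure `CCOc1nc2cccc(C(=O)Nc3ccc(S(N)(=O)=O)cc3)c2n1Cc1ccc(-c2ccccc2-c2nnn[nH]2)cc1`, and compound 2, with structure `CCOc1nc2cccc(C(=O)NCc3ccco3)c2n1Cc1ccc(-c2ccccc2-c2nnn[nH]2)cc1`, share one core and differ only in the group on the amide nitrogen. Going by the values given here, in an assay on isolated protein for inhibition of NEDD8-activating enzyme E1 regulatory subunit (Homo sapiens), read by Western blot, with stated times of 10 min and 30 min, tested at 25 uM (on this read-out higher numbers stand for more inhibition at the one concentration tested (going by the name of the read-out) and lower numbers for less inhibition), compound 1 gives 60.9%, while compound 2 gives 37.5%, so that the step of a number 23.4 percentage points lower from compound 1 to compound 2 (beyond the scatter); compound 2 therefore stands as the lower of the two numbers measured so far.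

Compound 3, with structure `CCOc1nc2cccc(C(=O)NCc3ccc(F)cc3)c2n1Cc1ccc(-c2ccccc2-c2nnn[nH]2)cc1`, is the next step from compound 2. The change is 4-fluorophenyl in place of furan-2-yl on a saturated chain carbon bound to an amide-type nitrogen. Among the compounds with values here, the one measured step, from compound 1 to compound 2, swapped an aromatic ring bound directly to the amide nitrogen for a five-membered ring on a chain carbon, a different kind of change from the ring-for-ring swap here, so it bears only loosely on what to expect. With no closer guide, the step of a number 4.5 percentage points higher from compound 2 to compound 3 (within the scatter) is expected to stay small, in no particular direction beyond the scatter. For compound 3 in this assay the estimate is 42%, within a range from 22% to 62%.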

Compound 3, a percentage reported as inhibition, at one concentration (the size of the read-out at that concentration, not a potency): 38.1%
Compound 3: the middle estimate sits 3.9 percentage points above what was measured, and the stated range covers the measured number.
By their numbers in this assay, from the lowest: compounds 2 and 3 (each within the scatter of the next); then compound 1.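

In this assay, 4-fluorophenyl in place of furan-2-yl on a saturated chain carbon bound to an amide-type nitrogen gives a number 0.6 percentage points higher from compound 2 to compound 3 (within the scatter), so a five-membered aromatic ring with one oxygen and a six-membered carbon-only ring carrying fluorine cannot be told apart at this place. Measured against compound 1, 4-fluorobenzyl in place of 4-sulfamoylphenyl gives a number 22.8 percentage points lower from compound 1 to compound 3 (beyond the scatter), so the gap first seen with the furan compound, a number 23.4 percentage points lower from compound 1 to compound 2 (beyond the scatter), is not particular to furan and appears with a second ring on a chain carbon. No measurement offered here explains either step or this gap.

The 4-sulfamoylphenyl group differs from both other groups in its substituent and in having its ring bound directly to the amide nitrogen, so these compounds cannot say which of the two features goes with the higher number for compound 1. On these data alone, an unsubstituted phenyl on the amide nitrogen and a sulfamoylbenzyl group would pull those two features apart, and an amine or a carboxylic acid on the chain-linked ring remains open as well.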